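Mirror image of an inactive cyclic amino acid

The source may report more compounds than this note shows. Statements on the series, on what has been measured and on what is new or still open speak of the compounds shown alone.

Compound 1, `N[C@@H](C(=O)O)[C@@H]1CC(O)=NO1`: in a functional assay on CHO cells with metabotropic glutamate receptor 1 (Rattus norvegicus) as the target, read by cAMP accumulation (a higher number here means that more compound is needed for the effect, a lower number that less compound is needed), compound 1 gives > 1000000 nM, a limit of the assay and not a number.
Compound 2, `N[C@@H](C(=O)O)[C@H]1CC(O)=NO1`: compound 2 gives > 1000000 nM, again a limit of the assay.
Compound 3, `NC(C(=O)O)C1CC(O)=NO1`: compound 3 gives 790000 nM; 110000 nM (2 entries).

Compound 2 therefore stands only at a limit; no single number is known for it. The step from compound 1 to compound 2, a step that the two limits leave unreadable from compound 1 to compound 2, cannot be read because the limit of > 1000000 nM in this assay, at which 2 of the 3 values shown sit, hides both ends, as the fact that compounds 1 and 2 differ only in the configuration as drawn shows. Compound 3, drawn without configuration, does give numbers, as the several entries of compound 3 in this assay, 790000 nM; 110000 nM (2 entries) records, and it differs from compound 2 only in that respect, as the fact that one of compounds 2 and 3 is drawn with a defined configuration and the other without, at the place where they differ states; some stereoisomer within compound 3 is thus active, while compound 1 and compound 2 are not.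

Compound 4, `N[C@H](C(=O)O)[C@@H]1CC(O)=NO1`, differs from compound 2 as follows: the two compounds have the same atoms and bonds and differ only in configuration as drawn: 2 of 2 stereo elements differ (all stereocentres are inverted: mirror images); a stereocentre at a saturated chain carbon is drawn R in compound 2 and S in compound 4; a stereocentre at a saturated ring carbon is drawn R in compound 2 and S in compound 4. Compound 4 is one of the two remaining stereoisomers hidden within compound 3, so it may be the active one, or may be as inactive as compound 2. The expected step in this assay is therefore an at least 3.3-fold lower number from compound 2 to compound 4 (0.52 log units; beyond the scatter), with a wide range. For compound 4 the estimate is 300000 nM, between 30000 nM and 1500000 nM.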

Compound 4, half-maximal effective concentration: 610000 nM
For compound 4 the middle estimate is 2.0-fold (0.31 log units) below the measured one; the range from low to high includes it.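

Going by these compounds alone, compound 4 is the first compound with a fully defined configuration to give a real number in this assay, so a measurable response no longer rests only on compound 3, which is drawn without configuration. The comparison with compound 1 isolates one stereocentre, the saturated chain carbon, drawn R in compound 1 and S in compound 4, and gives an at least 1.6-fold lower number from compound 1 to compound 4 (0.21 log units; that floor lies within the scatter), while inverting both stereocentres gives an at least 1.6-fold lower number from compound 2 to compound 4 (0.21 log units; that floor lies within the scatter). Each step is only a floor set by a limit of the assay, and each floor lies within the usual scatter, so the chain carbon becomes a candidate for what matters here, though a true gain is not established, and this single-centre reading rests on one comparison: the fact that compounds 1 and 4 differ only in the configuration as drawn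

The stereoisomer with the chain carbon drawn S and the ring carbon drawn R lies outside the compounds shown, so it remains open whether it would account for the lower of the entries of compound 3. Also open, from the compounds shown here alone, is whether a methyl ester in place of the carboxylic acid, or a longer chain carrying the amine and the acid, would keep any of this response.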